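Dropping the methyl from the pyrazole aryl ring

A few compounds are considered here, and "the series" means these few. Any claim that something is new, unique, unknown or untested is made for them only; others in the source may bear on it.

Measured compounds:
compound 1, `Cc1ccc(NC(=S)NC(=O)c2cn(-c3ccccc3)nc2-c2ccc(Cl)cc2)cc1`, 3120 nM
compound 2, `O=C(NC(=S)Nc1ccc(F)cc1)c1cn(-c2ccccc2)nc1-c1ccccc1`, 4210 nM
compound 3, `Cc1ccc(NC(=S)NC(=O)c2cn(-c3ccccc3)nc2-c2ccc(C)cc2)cc1`, 3760 nM

These three compounds share one core and were tested in a functional assay on NCI-H460 cells (Homo sapiens) for inhibition, read by CCK-8 assay, with a stated time of 48 h; on this read-out lower numbers stand for stronger inhibition and higher numbers for weaker inhibition. Compound 3 gives 3760 nM, and the numbers of compound 1 and compound 2 both lie within the scatter of it, so no ordering among the three can be claimed. Compound 4, `Cc1ccc(NC(=S)NC(=O)c2cn(-c3ccccc3)nc2-c2ccccc2)cc1`, is not yet measured. It differs from compound 3 by hydrogen in place of methyl on an aromatic carbon. Among the measured compounds shown here, only one measured step touches the same place: a 1.2-fold higher number from compound 1 to compound 3 (0.08 log units; within the scatter), where one group was swapped for another and nothing beyond the scatter followed. Compound 2 already carries a bare phenyl at that place, together with a different group on the thiourea aryl ring, and gives 4210 nM, again close to compound 3. Nothing in these data points to a step beyond the scatter in this assay . Compound 4 is therefore expected to land near compound 3, a step of a 1.0-fold higher number from compound 3 to compound 4 (0.02 log units; within the scatter), with an estimate of 3900 nM and a range from 2000 nM to 8000 nM.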

Compound 4, half-maximal inhibitory concentration: 3960 nM
Beside the measured number, compound 4's estimate is 1.0-fold (0.01 log units) below it; low and high end bracket the measured number.
By their numbers in this assay, from the lowest: compounds 1, 3, 4 and 2 (each within the scatter of the next).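

In this assay, taking the methyl off the 4-methylphenyl group to leave a phenyl gives a 1.1-fold higher number from compound 3 to compound 4 (0.02 log units; within the scatter), and the matching swap of chloro for hydrogen at this place gives a 1.3-fold higher number from compound 1 to compound 4 (0.10 log units; within the scatter), so hydrogen now joins methyl and chloro with no step beyond the scatter among the three. Among the compounds shown here, the one change elsewhere in the molecule, where fluoro gives way to methyl, gives a 1.1-fold lower number from compound 2 to compound 4 (0.03 log units; within the scatter) and so also stays within the scatter. Nothing measured here bears on why these numbers stay so close.

The compounds shown carry only hydrogen, methyl and chloro at this place, so whether an amine, a carboxylic acid or a longer chain there would give a step beyond the scatter remains open. As far as these compounds go, whether the same holds on other cell lines also remains open.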